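A few compounds are considered here, and "the series" means these few. Any claim that something is new, unique, unknown or untested is made for them only; others in the source may bear on it.

Compound 1, `CCc1cc(C(=O)N2CC=CC2)cc(C#N)c1O`, gives 54%.
Compound 2, `N#Cc1cc(C(=O)N2CC=CC2)cc(I)c1O`, gives 79%.
Compound 3, `Cc1cc(C(=O)N2CC=CC2)cc(C#N)c1O`, gives 25%.

These three numbers come from an assay on isolated protein for inhibition of solute carrier family 22 member 12 (Homo sapiens), tested at 3 uM; on this read-out higher numbers stand for more inhibition at the one concentration tested (going by the name of the read-out) and lower numbers for less inhibition. Compound 3 stands lowest of the three. Compound 1 is nearest to it, with the step of a number 29 percentage points lower from compound 1 to compound 3 (beyond the scatter), and compound 2 is furthest, with the step of a number 54 percentage points lower from compound 2 to compound 3 (beyond the scatter). Compound 4, `N#Cc1cc(C(=O)N2CC=CC2)cc(Br)c1O`, has not yet been measured. It differs from compound 3 in one place: bromo in place of methyl on an aromatic carbon.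

Within the data shown here, two measured steps bear on this change. The closest comparison is the step of a number 54 percentage points lower from compound 2 to compound 3 (beyond the scatter), which was large; read in the reverse direction it runs toward more inhibition. The step of a number 25 percentage points higher from compound 1 to compound 2 (beyond the scatter), iodo in place of ethyl, was modest and ran the same way. Bromo enters at the same aromatic carbon where iodo entered, so a rise in this assay is expected for compound 4, though it is uncertain whether the rise matches the iodo step. Compound 4 is therefore estimated at about 65%, in the range 45% to 85%. That estimate means an expected step of a number 40 percentage points higher from compound 3 to compound 4 (beyond the scatter), beyond the scatter.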

Compound 4, a percentage reported as inhibition, at one concentration (the size of the read-out at that concentration, not a potency): 69%
The estimate for compound 4 lay 4 percentage points below the measured number, within the range that was stated.
By their numbers in this assay, from the lowest: compound 3; then compound 1; then compounds 4 and 2 (each within the scatter of the next).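

In this assay, a number 44 percentage points higher from compound 3 to compound 4 (beyond the scatter) shows that the rise at this aromatic carbon, ortho to the hydroxy group, is not confined to iodo: a second halogen, bromo, also carries it when it replaces methyl. Bromo and iodo are not separated at this position, with a number 10 percentage points lower from compound 2 to compound 4 (within the scatter), while a number 15 percentage points higher from compound 1 to compound 4 (beyond the scatter) shows that bromo, like iodo, gives a reading beyond the scatter of the ethyl compound, so both halogen compounds stand clear of both alkyl compounds, and none of the four goes against this. Nothing available explains why these groups differ at this carbon.

The compounds shown leave open whether chloro or fluoro at the same carbon would read with bromo and iodo or nearer the alkyl groups, and whether a longer chain such as propyl would extend the gap seen from methyl to ethyl. They also leave open how a carboxylic acid or an amine at this carbon would read in this assay.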